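Cytotoxicity after swapping phenyl for propylamino on the carbonyl

A few compounds are considered here, and "the series" means these few. Any claim that something is new, unique, unknown or untested is made for them only; others in the source may bear on it.

Compound 2 `O=C(Nc1cc2nc(C3CCCCC3)[nH]c2cc1N1CCCC1)c1ccccc1` was examined in an ADME assay on Vero cells (Chlorocebus sabaeus) for cytotoxicity, read by resazurin assay, with a stated time of 3 days; a lower number here means a stronger inhibitor, a higher number a weaker inhibitor. In this assay compound 2 gives > 100 ug/mL, which is a limit of the assay rather than a measured number. Compound 1 `CCOCCOC(=O)Nc1cc2nc(C3CCCCC3)[nH]c2cc1N1CCCC1` likewise gives > 100 ug/mL in this assay, again a limit. The step that the two limits leave unreadable from compound 1 to compound 2 therefore cannot be read, since both values sit at the limit of > 100 ug/mL in this assay, at which 2 of the 2 values shown sit. Compound 3 `CCCNC(=O)Nc1cc2nc(C3CCCCC3)[nH]c2cc1N1CCCC1` has not yet been measured in this assay. It differs from compound 2 by propylamino in place of phenyl on a carbonyl carbon. Among the measured compounds shown here, no measured step bears on this change in a readable way: the only step recorded is unreadable, and compound 2 stands at the limit together with the other value shown. For compound 3 the expectation is no change beyond the scatter, with the step that the limit leaves unreadable from compound 2 to compound 3 expected to be small. Compound 3 is estimated at 120 ug/mL, between 50 ug/mL and 300 ug/mL, and will most likely again be reported only as a limit.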

Compound 3, half-maximal inhibitory concentration: > 100 ug/mL
Compound 3: no number, only a limit; the forecaster's own chance of this, stated with the estimate: 80%; the middle value does not contradict the limit.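

Compound 3, like compound 1 and compound 2, is reported in this assay only as a limit of the assay, so no step among these compounds can be read: the limit of > 100 ug/mL in this assay, at which 3 of the 3 values shown sit.

The compounds shown leave open whether phenyl, propylamino or 2-ethoxyethoxy on the carbonyl carbon makes any difference in this assay.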